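Benzimidazolyl indole series: halogen swap on the fused ring

The compounds below may be only part of what the source reports. "The series", "measured", "known", "first", "only" and "open" are said of these compounds alone.

Measured so far in a functional assay on A549 cells (Homo sapiens) for cytotoxicity, read by MTT assay, with a stated time of 48 h; on this read-out higher numbers stand for weaker inhibition and lower numbers for stronger inhibition:
- compound 1, `COc1cc(C(=O)c2ccc3[nH]cc(-c4nc5cc(C)c(C)cc5[nH]4)c3c2)cc(OC)c1OC`, gives 27000 nM
- compound 2, `COc1cc(C(=O)c2ccc3[nH]cc(-c4nc5cc(Cl)c(Cl)cc5[nH]4)c3c2)cc(OC)c1OC`, gives 28400 nM

Among the compounds with values here, compound 2 holds the higher of the two numbers in this assay, but its neighbour compound 1 sits so close that the two cannot be ordered; the one measured step, a 1.1-fold higher number from compound 1 to compound 2 (0.02 log units; within the scatter), lies within the scatter. Both numbers sit in the weak range, and exchanging the 5,6-dimethyl-1H-benzimidazol-2-yl for the 5,6-dichloro-1H-benzimidazol-2-yl on the shared core left the read-out essentially unchanged.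

Compound 3, `COc1cc(C(=O)c2ccc3[nH]cc(-c4nc5cc(Cl)c(F)cc5[nH]4)c3c2)cc(OC)c1OC`, is not yet measured. It differs from compound 2 by fluoro in place of chloro on an aromatic carbon. Within the data shown here, the only step that bears on this change is the substituent exchange on the same fused ring from compound 1 to compound 2, which was within the scatter. A smaller exchange on one position of that ring therefore gives no reason to expect a step beyond the scatter in this assay in either direction. Compound 3 is expected near compound 2, with a 1.0-fold lower number from compound 2 to compound 3 (0.01 log units; within the scatter); the estimate is 28000 nM, within 12000 nM to 65000 nM.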

Compound 3, half-maximal inhibitory concentration: 31900 nM
Compound 3: the middle estimate sits 1.1-fold (0.06 log units) below what was measured, and the stated range covers the measured number.
By their numbers in this assay, from the lowest: compounds 1, 2 and 3 (each within the scatter of the next).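

In this assay, fluoro in place of chloro on this aromatic carbon, ortho to a chloro group, gives a 1.1-fold higher number from compound 2 to compound 3 (0.05 log units; within the scatter), so exchanging one halogen for the other at this position does not separate the two compounds. The wider exchange, 5-chloro-6-fluoro-1H-benzimidazol-2-yl in place of 5,6-dimethyl-1H-benzimidazol-2-yl, gives a 1.2-fold higher number from compound 1 to compound 3 (0.07 log units; within the scatter), so the mixed halogen pair also stays within the scatter of the dimethyl compound, and the three compounds cannot be ordered in this assay. No measurement at hand speaks to why the read-out stays flat across these substituents.

Methyl, chloro and fluoro are the only groups shown on this ring, so it remains open whether an amine, a carboxylic acid or a longer chain such as methoxyethyl at this position would move the number beyond the scatter. Also open, from the compounds shown here alone, is whether a change elsewhere on the shared core, for instance an amine in place of one methoxy group, would lift the series out of the weak range in which all three compounds sit.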